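The source may hold more compounds than are shown below. What is called first, only, known or untested is meant among the compounds shown, and "the series" means these compounds.

Measured compounds:
Compound 1, `COc1ccc(C#Cc2csc(C)n2)cn1`: 426 nM
Compound 2, `C#Cc1nc(C#Cc2cccc(F)c2)cs1`: 2920 nM

In a functional assay on CHO cells for agonist activity at metabotropic glutamate receptor 5 (Homo sapiens), read by inositol phosphate accumulation (on this read-out higher numbers stand for weaker inhibition and lower numbers for stronger inhibition), compound 1 gives 426 nM. Compound 2, which shares the alkyne-linked thiazole motif but carries a different set of substituents, gives 2920 nM. Of the two numbers recorded in this assay, compound 1 stands at the lower one, and the gap to compound 2 is beyond the usual scatter of repeated measurements, so compound 1 is the stronger inhibitor of the pair. Going by the values given here, no pair of measured compounds differs in only one place, so no single-point step has yet been seen in this assay.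

Compound 3, `C=Cc1ccc(C#Cc2csc(C)n2)cn1`, is the next candidate and differs from compound 1 in one place: vinyl in place of methoxy on an aromatic carbon. Among the compounds with values here, with no comparable step measured, the direction of the change is uncertain; a small shift toward weaker inhibition is expected, of a size near the scatter, as the step of a 1.5-fold higher number from compound 1 to compound 3 (0.18 log units; within the scatter). Compound 3 is therefore expected to give about 650 nM in this assay, within a range from 250 nM to 1700 nM.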

Compound 3, half-maximal inhibitory concentration: > 10000 nM
Compound 3 ended at the assay's limit (the forecaster's own chance of this, stated with the estimate: 5%); at least 15-fold (1.18 log units) between middle value and limit.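

In this assay, the position on the six-membered aromatic ring with 1 nitrogen, next to the ring nitrogen, proves sensitive to the group it carries: vinyl in place of methoxy, with 2 heavy atoms on each side of the change, gives an at least 23-fold higher number from compound 1 to compound 3 (1.37 log units; beyond the scatter). Compound 3 sits at > 10000 nM, which is a limit of the assay and not a number: the limit of > 10000 nM in this assay, at which 1 of the 3 values shown sits. The change takes away the hydrogen-bond acceptor of the methoxy group and brings in a double bond outside aromatic rings, so the heavy-atom count alone does not set the outcome at this position, and this single step cannot separate the loss of the oxygen from the arrival of the double bond.

An ethyl group, which has neither oxygen nor double bond, and an ethoxy group, which keeps the oxygen, would help tell these two parts of the change apart at this position. Going by these compounds, it also stays open whether the same change would act alike on a core with other substituents, such as that of compound 2.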